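Adding a Second Fluoro Group to Compound 2

The source may report more compounds than this note shows. Statements on the series, on what has been measured and on what is new or still open speak of the compounds shown alone.

All three measured compounds were tested in a functional assay on RAW264.7 cells (Mus musculus), read by fluorescence; on this read-out lower numbers stand for stronger inhibition and higher numbers for weaker inhibition:

Compound 1 `CCOC(=O)C1=CCCCC1S(=O)(=O)Cc1ccc(Cl)cc1F`: 104 nM
Compound 2 `CCOC(=O)C1=CCCCC1S(=O)(=O)Cc1ccccc1F`: 97 nM
Compound 3 `CCOC(=O)C1=CCCCC1S(=O)(=O)Cc1ccc(Cl)cc1`: 101 nM

The three share one core and differ only in what sits on the aromatic ring. Compound 2 stands with the other two inside the scatter: the step of a 1.1-fold lower number from compound 1 to compound 2 (0.03 log units; within the scatter) and the step of a 1.0-fold higher number from compound 2 to compound 3 (0.02 log units; within the scatter) are both too small to count as real differences, and the same holds for a 1.0-fold lower number from compound 1 to compound 3 (0.01 log units; within the scatter).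

Compound 4 `CCOC(=O)C1=CCCCC1S(=O)(=O)Cc1cccc(F)c1F` is not yet measured. It differs from compound 2 by fluoro in place of hydrogen on an aromatic carbon, on an aromatic carbon of a six-membered aromatic ring of carbon only, ortho to a fluoro group and meta to a large group.

Within the data shown here, the steps that bear on this change are the ones that add or remove a halogen on the same ring: a 1.0-fold lower number from compound 1 to compound 3 (0.01 log units; within the scatter) removes a fluoro group, and a 1.1-fold lower number from compound 1 to compound 2 (0.03 log units; within the scatter) removes a chloro group, each without moving the number beyond the scatter. Adding one more fluoro group is therefore expected to leave this assay essentially unchanged, with a step of about a 1.0-fold higher number from compound 2 to compound 4 (0.01 log units; within the scatter) expected. Compound 4 is estimated at 100 nM, with a range from 50 nM to 200 nM.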

Compound 4, half-maximal inhibitory concentration: 100 nM
For compound 4 middle estimate and measured number coincide at the digits printed; low and high end bracket the measured number.
By their numbers in this assay, from the lowest: compounds 2, 4, 3 and 1 (each within the scatter of the next).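

Among these compounds, the step of a 1.0-fold higher number from compound 2 to compound 4 (0.01 log units; within the scatter) in this assay gives the first reading at this place, ortho to a fluoro group and meta to a large group, since none of the earlier compounds carries anything but hydrogen there. It shows that this place accepts a fluoro group without moving the number beyond the scatter, so a ring with two fluoro groups reads like the rings with one halogen or two different ones. Fluoro in place of hydrogen now also gives a comparable result in two separate pairs of compounds, so the flat result does not rest on a single pair:

the same change on two cores in this assay, a 1.0-fold lower number (0.01 log units; within the scatter) from compound 1 to compound 3 and a 1.0-fold lower number (0.01 log units; within the scatter) from compound 4 to compound 2, 1.0-fold (0.00 log units) apart, within the scatter of two such steps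

All four compounds carry only hydrogen, fluoro or chloro on the aromatic ring, so they leave open whether a methoxy group, an amine or a carboxylic acid at this place would also stay within the scatter. The ethyl ester and the sulfonyl group are the same throughout, so these compounds also cannot tell what a carboxylic acid in place of that ester would do to the number.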